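Methoxy to trifluoromethoxy: working notes on the series

The source may hold more compounds than are shown below. What is called first, only, known or untested is meant among the compounds shown, and "the series" means these compounds.

Values in a functional assay on HCT-116 cells (Homo sapiens) for inhibition (on this read-out lower numbers stand for stronger inhibition and higher numbers for weaker inhibition), follow.
- compound 1 `CC(=O)Oc1ccc(/C=C/c2ccc3ccccc3c2)cc1` gives a limit (> 5000 nM)
- compound 2 `Oc1ccc(/C=C/c2ccc3ccccc3c2)cc1` gives 4060 nM
- compound 3 `COc1ccc(/C=C/c2ccc3ccccc3c2)cc1` gives a limit (> 5000 nM)

Compound 3 has no number, only a limit (> 5000 nM). Its position is shared: the limit of > 5000 nM in this assay, at which 2 of the 3 values shown sit. The next structure is compound 4 `FC(F)(F)Oc1ccc(/C=C/c2ccc3ccccc3c2)cc1`, reached by trifluoromethyl in place of methyl on an oxygen on an aromatic ring.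

The bearing steps are other changes on that same oxygen. They are an at least 1.2-fold lower number from compound 1 to compound 2 (0.09 log units; that floor lies within the scatter) and an at least 1.2-fold higher number from compound 2 to compound 3 (0.09 log units; that floor lies within the scatter), and neither floor leaves the scatter. The third, a step that the two limits leave unreadable from compound 1 to compound 3, gives no size. On these data alone, on this evidence, no step beyond the scatter is expected in this assay, and no direction can be favoured, though the true size stays open.

The expected change is a step that the limit leaves unreadable from compound 3 to compound 4. For compound 4 the estimate is 6000 nM, within a range of 2500 nM to 15000 nM, and a report as a limit is expected to be the likelier outcome.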

Compound 4, half-maximal inhibitory concentration: > 5000 nM
Compound 4: only a limit was reported; the forecaster's own chance of this, stated with the estimate: 70%; the middle value lies beyond the limit too.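

In this assay compound 4 gives > 5000 nM, which is a limit and not a number. Trifluoromethyl in place of hydrogen on the oxygen on the aromatic ring gives an at least 1.2-fold higher number from compound 2 to compound 4 (0.09 log units; that floor lies within the scatter), so this change, like the earlier ones on that oxygen, shows no step beyond the scatter. The steps to compound 4 from compound 1 and from compound 3 cannot be read, and this change adds one more compound to the shared limit, with compound 2 the only one of the series that carries a number: the limit of > 5000 nM in this assay, at which 3 of the 4 values shown sit.

On these data alone, how far compound 1, compound 3 and compound 4 lie beyond their limits stays open, and with it whether these groups differ at all. Also open, as far as these compounds go, is whether an amine or a longer chain on that oxygen would give a readable number in this assay.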